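Phenyl in place of cycloheptyl on the amide nitrogen

The source may hold more compounds than are shown below. What is called first, only, known or untested is meant among the compounds shown, and "the series" means these compounds.

The three measured compounds and their values:
compound 1, `CCN(CC(=O)NC[C@H]1O[C@H](OC)[C@@H](OS(=O)(=O)O)[C@@H](OS(=O)(=O)O)[C@@H]1OS(=O)(=O)O)C(=O)COS(=O)(=O)O`: 512000 nM
compound 2, `CO[C@H]1O[C@H](CNC(=O)CN(Cc2ccccc2)C(C)=O)[C@@H](OS(=O)(=O)O)[C@H](OS(=O)(=O)O)[C@@H]1OS(=O)(=O)O`: 77000 nM
compound 3, `CO[C@H]1O[C@H](CNC(=O)CN(C(C)=O)C2CCCCCC2)[C@@H](OS(=O)(=O)O)[C@H](OS(=O)(=O)O)[C@@H]1OS(=O)(=O)O`: 3000000 nM

All three share the same sulfated core and differ only in what sits on the amide-type nitrogen of the side chain. In an assay on isolated protein for binding affinity to vascular endothelial growth factor A, long form (Homo sapiens), read by surface plasmon resonance (on this read-out lower numbers stand for tighter binding and higher numbers for weaker binding), compound 1 gives 512000 nM, compound 2 gives 77000 nM and compound 3 gives 3000000 nM, the highest of the three numbers. The steps leading to it are a 5.9-fold higher number from compound 1 to compound 3 (0.77 log units; beyond the scatter) and a 39-fold higher number from compound 2 to compound 3 (1.59 log units; beyond the scatter), while a 6.6-fold lower number from compound 1 to compound 2 (0.82 log units; beyond the scatter).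

Compound 4, `CO[C@H]1O[C@H](CNC(=O)CN(C(C)=O)c2ccccc2)[C@@H](OS(=O)(=O)O)[C@H](OS(=O)(=O)O)[C@@H]1OS(=O)(=O)O`, is not yet measured. It differs from compound 3 by phenyl in place of cycloheptyl on an amide-type nitrogen. Within the data shown here, the step that bears most directly on this change is the one from compound 2 to compound 3, where a saturated seven-membered ring replaced an aromatic ring on the same nitrogen and the number rose by a large amount. Returning to an aromatic ring, now attached directly rather than through a methylene, is therefore expected to send the number back down, though the exact size is uncertain. For compound 4 the expected step is a 20-fold lower number from compound 3 to compound 4 (1.30 log units; beyond the scatter), giving an estimated value of 150000 nM with a range from 40000 nM to 700000 nM.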

Compound 4, dissociation constant: 76000 nM
Beside the measured number, compound 4's estimate is 2.0-fold (0.30 log units) above it; the measured number falls inside the stated range.
By their numbers in this assay, from the lowest: compounds 4 and 2 (each within the scatter of the next); then compound 1; then compound 3.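

Phenyl on the amide-type nitrogen recovers what cycloheptyl lost in this assay, with a 39-fold lower number from compound 3 to compound 4 (1.60 log units; beyond the scatter), so the weak binding of compound 3 is not a feature of this position as such but goes with the cycloheptyl group there. The earlier compounds had shown only benzyl as an aromatic group at this nitrogen; now, with a 1.0-fold lower number from compound 2 to compound 4 (0.01 log units; within the scatter), phenyl and benzyl cannot be told apart, and the aromatic ring need not be held on a chain carbon for the number to stay in this range, while compound 4 also keeps the gain over the ethyl compound, with a 6.7-fold lower number from compound 1 to compound 4 (0.83 log units; beyond the scatter). Nothing measured here explains why these groups differ, and no supporting data on the cause are available.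

Going by these compounds, it remains open whether cyclohexyl, with the same ring size as phenyl but saturated, would fall with cycloheptyl or with the two aromatic groups, and whether a longer chain such as phenethyl would hold the number of compound 4. Also unresolved is what a carboxylic acid or an amine on the phenyl ring would do to binding.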